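The source may hold more compounds than are shown below. What is called first, only, known or untested is meant among the compounds shown, and "the series" means these compounds.

Measured in a physicochemical assay for lipophilicity (on this read-out higher numbers stand for higher lipophilicity and lower numbers for lower lipophilicity), so far:
- Compound 1 `C[C@H]1CC[C@@H]2[C@@H](OC(=O)[C@]23CC(c2ccccc2F)=NO3)[C@]2(C)C(=O)C=C[C@@]12O` gives 1.58
- Compound 2 `C[C@H]1CC[C@@H]2[C@@H](OC(=O)[C@]23CC(c2ccc(C#N)cc2)=NO3)[C@]2(C)C(=O)C=C[C@@]12O` gives 1.17
- Compound 3 `Cc1ccccc1C1C[C@@]2(ON1c1ccccc1)C(=O)O[C@@H]1[C@H]2CC[C@H](C)[C@]2(O)C=CC(=O)[C@@]12C` gives 3.64

Compound 3 stands highest of the three, at 3.64 on this scale. Compound 4 `C[C@H]1CC[C@@H]2[C@@H](OC(=O)[C@]23CC(c2ccccc2Cl)N(c2ccccc2)O3)[C@]2(C)C(=O)C=C[C@@]12O` departs from it by chloro in place of methyl on an aromatic carbon in words: chloro in place of methyl on an aromatic carbon, ortho to a large group, or 2-methylphenyl to 2-chlorophenyl. Going by the values given here, no measured step covers this exchange. Among the compounds with values here, the one step available, a number 0.41 log units lower from compound 1 to compound 2 (beyond the scatter), involves other groups at another place and bears on it only loosely. No change beyond the scatter is expected in this assay here. The estimated step is a number 0.06 log units higher from compound 3 to compound 4 (within the scatter) and would stay within the scatter. For compound 4 the expected value is 3.7 with an estimated range from 3.3 to 4.1 overall.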

Compound 4, partition coefficient: 3.87
The estimate for compound 4 lay 0.17 log units below the measured number, and the stated range covers the measured number.
By their numbers in this assay, from the lowest: compound 2; then compound 1; then compounds 3 and 4 (each within the scatter of the next).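

In this assay, chloro in place of methyl on an aromatic carbon, ortho to a large group, gives a number 0.23 log units higher from compound 3 to compound 4 (within the scatter) and so does not separate the two groups at this position. Going by these compounds alone, this is the first step read at this place, since the only earlier step involved other groups elsewhere on the core. What the compounds leave open is whether an amine or a carboxylic acid on this aromatic carbon would move the number beyond the scatter. No evidence at hand gives a reason for this result.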